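The source may report more compounds than this note shows. Statements on the series, on what has been measured and on what is new or still open speak of the compounds shown alone.

In a functional assay on U-937 cells (Homo sapiens) for antiproliferative activity, read by MTT assay, with a stated time of 24 h (on this read-out higher numbers stand for weaker inhibition and lower numbers for stronger inhibition), compound 1 `CCCCc1oc2ccccc2c1C(=O)c1ccc(OCC(=O)N2CCCCC2)cc1` gives 37100 nM, compound 2 `CCCCc1oc2ccccc2c1C(=O)c1ccc(OCC(=O)N2CCN(C(=O)OC(C)(C)C)CC2)cc1` gives 23700 nM and compound 3 `CCCCc1oc2ccccc2c1C(=O)c1ccc(OCC(=O)Nc2cccc(OC)c2)cc1` gives 24200 nM. Compound 3 lies within the scatter of both others, so these values set no ranking. Compound 4 `CCCCc1oc2ccccc2c1C(=O)c1ccc(OCCCC(=O)N2CCCCC2)cc1` differs from compound 3 by 2-((piperidin-1-yl)carbonyl)ethyl in place of (3-methoxyphenyl)carbamoyl on a saturated chain carbon bound to an oxygen on an aromatic ring: 2-((piperidin-1-yl)carbonyl)ethyl stands in place of (3-methoxyphenyl)carbamoyl. Among the measured compounds shown here, the only measured step that bears on this is a 1.5-fold lower number from compound 1 to compound 3 (0.19 log units; within the scatter), which exchanges the same amide partners in the opposite sense and stays within the scatter. For the measured compounds named here, no measured step tests the chain itself. No change beyond the scatter is therefore expected in this assay, and the estimated step is a 1.2-fold higher number from compound 3 to compound 4 (0.09 log units; within the scatter). For compound 4 the expected value is 30000 nM, with an estimated range from 14000 nM to 60000 nM.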

Compound 4, half-maximal inhibitory concentration: 16600 nM
Compound 4: the middle estimate sits 1.8-fold (0.26 log units) above what was measured; low and high end bracket the measured number.
By their numbers in this assay, from the lowest: compounds 4, 2, 3 and 1 (each within the scatter of the next, the first and the last beyond it).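

In this assay, keeping the piperidin-1-yl amide and lengthening only the chain on the oxygen gives a 2.2-fold lower number from compound 1 to compound 4 (0.35 log units; beyond the scatter), a modest change and the first measured effect of that chain. Exchanging the (3-methoxyphenyl)carbamoyl group for the longer piperidine amide gives a 1.5-fold lower number from compound 3 to compound 4 (0.16 log units; within the scatter), so these two compounds remain unseparated. No available evidence explains the effect of the chain.

From the compounds shown here alone, whether a still longer chain would lower the number further remains open. So does the effect of a carboxylic acid or an amine at the end of the chain in place of the amide.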